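The source may report more compounds than this note shows. Statements on the series, on what has been measured and on what is new or still open speak of the compounds shown alone.

Measured compounds:
Compound 1 `COc1ccc2[nH]c3c(c2c1)CCNC31CCN(Cc2ccccc2)CC1`: 12600 nM
Compound 2 `COc1ccc2[nH]c3c(c2c1)CCNC31CCN(Cc2cc(F)cc(Cl)c2)CC1`: 2500 nM

Going by the values given here, in an assay on FRT cells for positive allosteric modulation of Cystic fibrosis transmembrane conductance regulator variant N1303K (Homo sapiens), in the presence of a further agent that is not named here (a lower number here means that less compound is needed, a higher number that more compound is needed for the effect), compound 2 gives the lower of the two numbers so far; its nearest neighbour is compound 1, which in this assay gives 12600 nM. Compound 3 `COc1ccc2[nH]c3c(c2c1)CCNC31CCN(Cc2ccc(F)c(Cl)c2F)CC1` differs from compound 2 in one place: 3-chloro-2,4-difluorophenyl in place of 3-chloro-5-fluorophenyl on a saturated chain carbon bound to an amine nitrogen in a ring. Among the compounds with values here, only one measured step bears on this change, the step of a 5.0-fold lower number from compound 1 to compound 2 (0.70 log units; beyond the scatter), in which a halogenated phenyl replaced a plain phenyl at the same place. That step shows a substituted ring helps there, but it does not tell how a different halogen arrangement on an already substituted ring will read. Compound 3 keeps a chloro and fluoro ring at this place, so a number close to that of compound 2 is expected, with the direction uncertain; the expected step of no change at the digits printed from compound 2 to compound 3 (within the scatter) lies within the scatter. For compound 3 an estimate of 2500 nM in this assay is made, within a range of 800 nM to 8000 nM.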

Compound 3, half-maximal effective concentration: 4500 nM
Beside the measured number, compound 3's estimate is 1.8-fold (0.26 log units) below it; the range from low to high includes it.
By their numbers in this assay, from the lowest: compounds 2 and 3 (each within the scatter of the next); then compound 1.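

In this assay, 3-chloro-2,4-difluorophenyl in place of 3-chloro-5-fluorophenyl on a saturated chain carbon bound to an amine nitrogen in a ring gives a 1.8-fold higher number from compound 2 to compound 3 (0.26 log units; within the scatter), so the two halogenated rings cannot be told apart here, despite the added fluorine and the different arrangement. Set against plain phenyl, the new ring gives a 2.8-fold lower number from compound 1 to compound 3 (0.45 log units; beyond the scatter), which shows that the advantage of a halogenated ring over phenyl at this place holds for two halogen arrangements and not only for the one in compound 2. Nothing available explains these readings.

Still open, on these data alone, is whether this place needs halogens at all, or whether a methoxy group, a nitrile or a carboxylic acid on the ring would read the same. Also open, as far as these compounds go, is how a pyridine in place of the halogenated phenyl would read in this assay.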